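Carbonyl substituent change from compound 2 to compound 4

This account rests on a few compounds, and the source may have more. Where it says the series, first, only, none or still open, it means among the compounds named here.

Measured so far in an assay on isolated protein for inhibition of Rho-associated protein kinase 2 (Homo sapiens), read by scintillation counting, radiometric assay and 33P incorporation, with a stated time of 40 min, in the presence of a further agent that is not named here; a lower number here means a stronger inhibitor, a higher number a weaker inhibitor:
compound 1 `CN(C)c1ccc(C(=O)Nc2cccc(NC(=O)COc3ccc4c(c3)OCCO4)c2)cc1`: > 10000 nM
compound 2 `CCCC(=O)Nc1cccc(NC(=O)COc2ccc3c(=O)ccoc3c2)c1`: 176 nM
compound 3 `O=C(COc1ccc2c(=O)ccoc2c1)Nc1cccc(NC(=O)c2cccc([N+](=O)[O-])c2)c1`: 41 nM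

The value of compound 1 is a limit of this assay and not a number (the limit of > 10000 nM in this assay, at which 1 of the 3 values shown sits). Among the compounds with values here, compound 2 stands highest of the two numbers; its nearest neighbour is compound 3, and the step of a 4.3-fold lower number from compound 2 to compound 3 (0.63 log units; beyond the scatter) is the only measured step that bears on the change below.

Compound 4 `CC(C)(C)c1cc(C(=O)Nc2cccc(NC(=O)COc3ccc4c(=O)ccoc4c3)c2)no1` differs from compound 2 by 5-(tert-butyl)-1,2-oxazol-3-yl in place of propyl on a carbonyl carbon. Within the data shown here, the one relevant step, from a chain to an aromatic ring on the same carbonyl carbon, gave a modest gain, so a step of similar size toward a lower number is expected here, a 2.9-fold lower number from compound 2 to compound 4 (0.47 log units; beyond the scatter). Compound 4 is estimated at 60 nM, with a range from 20 nM to 200 nM.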

Compound 4, half-maximal inhibitory concentration: 5 nM
Compound 4: middle estimate off by 12-fold (1.08 log units), on the high side; the whole stated range lies above it.
By their numbers in this assay, from the lowest: compound 4; then compound 3; then compound 2. At a limit, above all of these: compound 1.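

Replacing propyl on this carbonyl carbon brings a 35-fold lower number from compound 2 to compound 4 (1.55 log units; beyond the scatter), a large step that shows this position can yield far more than the 3-nitrophenyl group suggested. The choice of ring also matters, since exchanging 3-nitrophenyl for 5-(tert-butyl)-1,2-oxazol-3-yl gives an 8.2-fold lower number from compound 3 to compound 4 (0.91 log units; beyond the scatter) on the same carbonyl carbon. Nothing measured here accounts for this gain.

As far as these compounds go, whether it rests on the tert-butyl group or on the five-membered aromatic ring remains open. Also open, from the compounds shown here alone, is how a primary amine or a carboxylic acid on that ring would fare.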